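Thiophene for phenyl on an N-methylated pyrimidine hydrazide series

This account rests on a few compounds, and the source may have more. Where it says the series, first, only, none or still open, it means among the compounds named here.

Measured so far:
compound 1, `CCOC(=O)c1cnc(-c2cccs2)nc1NN1C(=O)C=C(C)C1=O`, 20 nM
compound 2, `CCOC(=O)c1cnc(-c2ccccc2)nc1N(C)N1C(=O)C=C(C)C1=O`, 2000 nM
compound 3, `CCOC(=O)c1cnc(-c2ccccc2)nc1N(C(C)=O)N1C(=O)C=C(C)C1=O`, 4000 nM

In a functional assay on Jurkat cells for inhibition of nuclear factor NF-kappa-B complex (Homo sapiens) (on this read-out higher numbers stand for weaker inhibition and lower numbers for stronger inhibition), compound 2 stands second highest of the three numbers. Its nearest neighbour is compound 3, reached by a 2.0-fold higher number from compound 2 to compound 3 (0.30 log units; within the scatter), a change of acetyl for methyl. Compound 1 sits far lower, but it differs from compound 2 in two places at once, so its gap tells nothing clean about either change on its own.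

Compound 4, `CCOC(=O)c1cnc(-c2cccs2)nc1N(C)N1C(=O)C=C(C)C1=O`, keeps the methyl of compound 2 and makes one change: thiophen-2-yl in place of phenyl on an aromatic carbon. For the measured compounds named here, no measured step matches this exchange. Compound 1 carries the same thiophen-2-yl and gives 20 nM, while compound 2 gives 2000 nM, yet the hydrogen-for-methyl difference also lies between them. The two changes cannot be separated from these two values alone.

The expectation therefore leans toward a lower number, though with wide uncertainty, as the estimated step of a 2.5-fold lower number from compound 2 to compound 4 (0.40 log units; beyond the scatter) shows. Compound 4 is estimated at 800 nM in this assay, within 150 nM to 4000 nM.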

Compound 4, half-maximal inhibitory concentration: 1000 nM
Estimate against measurement, compound 4: 1.3-fold (0.10 log units) below, within the range that was stated.
By their numbers in this assay, from the lowest: compound 1; then compounds 4, 2 and 3 (each within the scatter of the next, the first and the last beyond it).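

In this assay, with the methyl on the nitrogen kept, thiophen-2-yl in place of phenyl on the aromatic carbon between two ring nitrogen atoms gives a 2.0-fold lower number from compound 2 to compound 4 (0.30 log units; within the scatter), so at this position the exchange alone does not move the number beyond the scatter. For the compounds shown here, with thiophen-2-yl kept, methyl in place of hydrogen on the nitrogen gives a 50-fold higher number from compound 1 to compound 4 (1.70 log units; beyond the scatter), which shows that of the two changes the opening values could not separate, the change on the nitrogen is the one with a large step behind it. Nothing available explains why the hydrogen on this nitrogen matters so much.

Going by these compounds, it remains open whether the thiophen-2-yl and phenyl groups would also stay within the scatter of each other with hydrogen on the nitrogen, and whether a furan-2-yl or pyridine ring would fit at the same carbon. Also open, on these data alone, is how an ethyl group or a longer chain on that nitrogen would compare with methyl.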